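The source may report more compounds than this note shows. Statements on the series, on what has been measured and on what is new or still open speak of the compounds shown alone.

Measured so far in an ADME assay on Vero cells (Chlorocebus sabaeus) for cytotoxicity, read by MTT assay, with a stated time of 96 h (a higher number here means that more compound is tolerated, a lower number that less compound is tolerated), each value a limit and not a number:
- compound 1 `CC(=O)c1ccc2[nH]c(-c3ccc(Cl)cc3)nc2c1`: > 100000 nM
- compound 2 `CC(=O)c1ccc2[nH]c(-c3ccc(C(F)(F)F)cc3)nc2c1`: > 100000 nM
- compound 3 `COc1ccc(-c2nc3cc(C(C)=O)ccc3[nH]2)c(OC)c1`: > 100000 nM

Compound 3 stands at > 100000 nM, which is a limit and not a number. The same holds across the series: the limit of > 100000 nM in this assay, at which 3 of the 3 values shown sit. No measured number therefore places compound 3 above or below the other two.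

The next compound is compound 4 `COc1ccc(-c2nc3cc(C(C)=O)ccc3[nH]2)c(OC)c1OC`, which carries methoxy in place of hydrogen on an aromatic carbon, ortho to two methoxy groups and meta to a large group: methoxy in place of hydrogen on an aromatic carbon.

Among the compounds with values here, the only measured step is a step that the two limits leave unreadable from compound 1 to compound 2, with trifluoromethyl in place of chloro on an aromatic carbon. Within the data shown here, it gives no size to carry over, and no measured step involves methoxy in place of hydrogen.

Among the measured compounds shown here, no large step is expected in this assay because compound 3 gives > 100000 nM, a limit, and no compound here has yet given a number. The expected change is a number no higher from compound 3 to compound 4 (the limit leaves the size open), and a reading at the same limit is the likeliest outcome. For compound 4 the estimate is 100000 nM, with an expected range from 40000 nM to 250000 nM.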

Compound 4, half-maximal cytotoxic concentration: > 100000 nM
Compound 4: only a limit was reported; the forecaster's own chance of this, stated with the estimate: 75%; the middle value sits exactly at the limit.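

In this assay compound 4 gives > 100000 nM, a limit and not a number. Within the data shown here, no step from compound 3 to compound 4 can be read, and the series offers one shared reading: the limit of > 100000 nM in this assay, at which 4 of the 4 values shown sit. The compounds shown leave open at what concentration any of them becomes cytotoxic, and whether methoxy in place of hydrogen alters that concentration.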